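A few compounds are considered here, and "the series" means these few. Any claim that something is new, unique, unknown or untested is made for them only; others in the source may bear on it.

Working notes on the dichloroacetamide series, read in a functional assay on NCI-H460 cells (Homo sapiens) for cytotoxicity, read by MTT assay, with a stated time of 68 h; on this read-out lower numbers stand for stronger inhibition and higher numbers for weaker inhibition. Compound 1 `O=C(Nc1cccc(-c2ccccc2C(F)(F)F)c1)C(Cl)Cl` gives 7550 nM in this assay, and compound 2 `O=C(Nc1cccc(-c2ccc(-c3ccccc3)cc2)c1)C(Cl)Cl` gives 10900 nM; the two values lie within the usual scatter of each other. Compound 3 `COc1cccc(-c2cc(NC(=O)C(Cl)Cl)cc(-c3cccc(OC)c3)c2)c1` carries two 3-methoxyphenyl groups and reaches only the limit of the assay, reported as > 30000 nM. Among the measured compounds shown here, compound 3 thus stands at the limit of > 30000 nM in this assay, at which 1 of the 3 values shown sits, so no number is known for it and no measured step between any pair of compounds can be drawn. Compound 4 `COc1cccc(-c2cccc(NC(=O)C(Cl)Cl)c2)c1` is the unmeasured member and differs from compound 3 in one place: hydrogen in place of 3-methoxyphenyl on an aromatic carbon. The change removes one of the two 3-methoxyphenyl groups and leaves a compound built like compound 1 at 7550 nM and compound 2 at 10900 nM. A step toward stronger inhibition, from the limit down into that range, is expected for compound 4, of about an at least 3.0-fold lower number from compound 3 to compound 4 (0.47 log units; beyond the scatter), though the limit on compound 3 leaves the true size open. Compound 4 is expected to give about 10000 nM in this assay, within 4000 nM to 30000 nM.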

Compound 4, half-maximal inhibitory concentration: 33800 nM
Compound 4: middle estimate off by 3.4-fold (0.53 log units), on the low side, and the stated range ends below it.
By their numbers in this assay, from the lowest: compounds 1 and 2 (each within the scatter of the next); then compound 4.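

No step can be read from compound 3 to compound 4, because compound 3 carries a limit and not a number: the limit of > 30000 nM in this assay, at which 1 of the 4 values shown sits.

The compounds shown leave open whether hydrogen in place of 3-methoxyphenyl on an aromatic carbon changes the read-out at all, and by how much.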